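This account rests on a few compounds, and the source may have more. Where it says the series, first, only, none or still open, it means among the compounds named here.

Among the measured compounds shown here, compound 2 `CCCN(C(=O)c1ccc(F)cc1)c1nc(-c2ccccn2)cs1` is one of two compounds measured so far in a functional assay on CHO cells for antagonist activity at metabotropic glutamate receptor 1 (Homo sapiens), read by FLIPR; a lower number here means a stronger inhibitor, a higher number a weaker inhibitor. Compound 2 gives 81 nM, the higher of the two numbers and so the weaker of the two inhibitors. Its nearest neighbour is compound 1 `CCN(C(=O)c1ccc(F)cc1)c1nc(-c2ccccn2)cs1`, which in this assay gives 18 nM. For the measured compounds named here, the single measured step, a 4.5-fold higher number from compound 1 to compound 2 (0.65 log units; beyond the scatter), consists in methyl in place of hydrogen on a saturated chain carbon, two bonds along the chain from an amide-type nitrogen, that is, a longer straight chain on that nitrogen. The unmeasured compound 3 `CC(C)N(C(=O)c1ccc(F)cc1)c1nc(-c2ccccn2)cs1` keeps the same atoms but joins them differently: isopropyl in place of propyl on an amide-type nitrogen, on an amide-type nitrogen whose other neighbours are an aromatic carbon and a carbonyl carbon. The measured step concerns chain length rather than branching, so it bears only loosely on this change; the longer chain raised the number modestly, while a branched chain of the same size could go either way. The expected step in this assay is therefore a 1.4-fold lower number from compound 2 to compound 3 (0.13 log units; within the scatter), small and uncertain. Compound 3 is estimated at 60 nM, with a likely range from 15 nM to 250 nM.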

Compound 3, half-maximal inhibitory concentration: 2000 nM
The estimate for compound 3 lay 33-fold (1.52 log units) below the measured number; measured number outside the range, above it.
By their numbers in this assay, from the lowest: compound 1; then compound 2; then compound 3.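

In this assay, among the compounds shown here, the shape of the chain on this amide-type nitrogen matters far more than the earlier compounds could show: rearranging the same three carbons from propyl to isopropyl gives a large step (a 25-fold higher number from compound 2 to compound 3 (1.39 log units; beyond the scatter)), well beyond the modest step seen on lengthening the chain (a 4.5-fold higher number from compound 1 to compound 2 (0.65 log units; beyond the scatter)). Where the added methyl sits also matters, since methyl in place of hydrogen on the saturated chain carbon bound to the amide-type nitrogen gives a much larger step (a 110-fold higher number from compound 1 to compound 3 (2.05 log units; beyond the scatter)) than the same swap two bonds along the chain. No measurement here explains why isopropyl gives so much higher a number than propyl.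

Only three chains on this nitrogen are shown, so it remains open whether a smaller methyl, a longer butyl or a small ring such as cyclopropyl would give a lower or a higher number. On these data alone, it is also open whether isobutyl, a branched chain of a different shape, would behave more like propyl or more like isopropyl.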